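Urea-linked pyrazoles: trading trifluoromethyl for chloro

The source may report more compounds than this note shows. Statements on the series, on what has been measured and on what is new or still open speak of the compounds shown alone.

Measured so far:
- compound 1, `O=C(Nc1cccc(-n2cc(-c3ccncc3)c(-c3cc(O)cc(Cl)c3)n2)c1)Nc1ccc(Cl)c(Cl)c1`, 96%
- compound 2, `COc1cc(Cl)cc(-c2nn(-c3cccc(NC(=O)Nc4ccc(Cl)c(C(F)(F)F)c4)c3)cc2-c2ccncc2)c1`, 91%

In a functional assay on UACC-257 cells (Homo sapiens) for inhibition, read by sulforhodamine B assay, with a stated time of 48 h, tested at 0.01 uM (on this read-out lower numbers stand for a stronger effect and higher numbers for a weaker effect at the one concentration tested), compound 1 gives 96%. In this assay compound 2 gives 91%, a number that sits within the scatter of compound 1, so the two cannot be told apart on this read-out. Among the compounds with values here, both numbers are high, meaning that at the single concentration tested neither compound shows much effect on cell growth.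

Compound 3, `COc1cc(Cl)cc(-c2nn(-c3cccc(NC(=O)Nc4ccc(Cl)c(Cl)c4)c3)cc2-c2ccncc2)c1`, is not yet measured. It differs from compound 2 in one place: chloro in place of trifluoromethyl on an aromatic carbon. Within the data shown here, no measured pair shows this exact change in isolation. Compound 1 already carries the dichlorophenyl end group and gives 96%, a high number. Compound 3 is therefore expected to remain in the same high region, with no step beyond the scatter, so the estimated step of a number 3 percentage points higher from compound 2 to compound 3 (within the scatter) is small. For compound 3 the estimate in this assay is 94%, within a range from 82% to 103%.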

Compound 3, a percentage reported as activity, at one concentration (the size of the read-out at that concentration, not a potency): 96%
The estimate for compound 3 lay 2 percentage points below the measured number; the range from low to high includes it.
By their numbers in this assay, from the lowest: compounds 2, 1 and 3 (each within the scatter of the next).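

Chloro in place of trifluoromethyl on an aromatic carbon gives a number 5 percentage points higher from compound 2 to compound 3 (within the scatter) in this assay and is now seen on its own, with nothing else in the molecule changing, so at this place the swap shows no effect that can be told from the scatter. Compound 3 also makes a second single-change pair possible: methyl in place of hydrogen on an oxygen on an aromatic ring gives no change at the digits printed from compound 1 to compound 3 (within the scatter) and likewise cannot be told from the scatter. Nothing available here offers an explanation for either result.

All three compounds lie within the scatter of one another, so this read-out does not rank them. On these data alone, whether an amine or a carboxylic acid at the place of the chloro or trifluoromethyl would change the number remains open.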